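Swapping Bromo for Chloro in a Bromophenyl Amide Series

The source may report more compounds than this note shows. Statements on the series, on what has been measured and on what is new or still open speak of the compounds shown alone.

Measured so far:
compound 1 `C#CCNC(=O)/C(C)=C(\C)c1ccc(Br)cc1`: 150 mg/kg
compound 2 `C/C(C(=O)NC1CC1)=C(/C)c1ccc(Br)cc1`: 130 mg/kg

In a toxicity assay on the whole organism (strain Icem-CET (SPF Caw)) for cytotoxicity, with Mus musculus as the target (on this read-out higher numbers stand for an effect only at larger amounts of compound and lower numbers for an effect already at smaller amounts), compound 1 gives 150 mg/kg, and compound 2 gives 130 mg/kg. Going by the values given here, compound 2 carries the lowest of the two numbers, but its only neighbour is compound 1, and the difference a 1.2-fold lower number from compound 1 to compound 2 (0.06 log units; within the scatter) is within the scatter, so the two compounds cannot be told apart on this read-out.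

Compound 3 `C/C(C(=O)NC1CC1)=C(/C)c1ccc(Cl)cc1` is not yet measured. It differs from compound 2 in one place: chloro in place of bromo on an aromatic carbon. Among the compounds with values here, the single measured step, from propargyl to cyclopropyl on the amide nitrogen, concerns a different part of the molecule and was within the scatter, so no measured step bears directly on a halogen exchange on the aromatic ring. With nothing pointing either way, no step beyond the scatter is expected in this assay. The expected step for compound 3 is a 1.1-fold higher number from compound 2 to compound 3 (0.03 log units; within the scatter). Compound 3 is therefore estimated at 140 mg/kg, within a range of 90 mg/kg to 220 mg/kg.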

Compound 3, dose for half-maximal effect: 150 mg/kg
Compound 3: middle estimate off by 1.1-fold (0.03 log units), on the low side; measured number inside the range.
By their numbers in this assay, from the lowest: compounds 2, 1 and 3 (each within the scatter of the next).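

In this assay, chloro in place of bromo on an aromatic carbon gives a 1.2-fold higher number from compound 2 to compound 3 (0.06 log units; within the scatter), which lies within the scatter. Going by these compounds alone, the earlier step changed only the group on the amide nitrogen, so this is the first look at the aromatic ring, and at this position the two halogens cannot be told apart on this read-out. No separate measurement on these compounds bears on this result.

Both steps shown stay within the scatter, so neither place has yet been seen to affect the read-out. On these data alone, it remains open whether a group of a different kind on that aromatic carbon, such as an amine or a carboxylic acid, or a longer chain on the amide nitrogen, would give a step beyond the scatter.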